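From a Diol Amide to a Cyclohexyl Amide

The compounds below may be only part of what the source reports. "The series", "measured", "known", "first", "only" and "open" are said of these compounds alone.

Compound 1 `COCCNC(=O)c1cc2cccc(OC)c2oc1=N` — 15%
Compound 2 `N=c1oc2ccc(Br)cc2cc1C(=O)NCC(O)CO` — 10%

Of the compounds shown here, two have been measured in an assay on HeLa cells for displacement of a labelled ligand from adenosine receptor A3 (Homo sapiens), read by scintillation counting, with a stated time of 180 min, tested at 10 uM; on this read-out lower numbers stand for less inhibition and higher numbers for more inhibition at the one concentration tested (going by the name of the read-out). Going by the values given here, compound 2 gives 10% in this assay, and the number for compound 1, the only other measurement, lies within the usual scatter of it, so the two cannot be told apart on these data. Compound 3 `N=c1oc2ccc(Br)cc2cc1C(=O)NC1CCCCC1` has not yet been measured. It differs from compound 2 in one place: cyclohexyl in place of 2,3-dihydroxypropyl on an amide-type nitrogen. Among the compounds with values here, no step between measured compounds connects the two, and no measured pair alters the group on the amide-type nitrogen, so the size of this step has no measured counterpart to lean on. Both measured values are low, and the change is expected to move the number only modestly, upward if at all, quite possibly not beyond the scatter. The step of a number 10 percentage points higher from compound 2 to compound 3 (within the scatter) is expected to be small and upward. Compound 3 is estimated at 20% in this assay, with a range from 5% to 45% reflecting how little the measured compounds constrain it.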

Compound 3, a percentage reported as inhibition, at one concentration (the size of the read-out at that concentration, not a potency): 8%
For compound 3 the middle estimate is 12 percentage points above the measured one, within the range that was stated.
By their numbers in this assay, from the lowest: compounds 3, 2 and 1 (each within the scatter of the next).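

In this assay, going by these compounds alone, the change from 2,3-dihydroxypropyl to cyclohexyl on the amide-type nitrogen gives a number 2 percentage points lower from compound 2 to compound 3 (within the scatter), and this is the first measured step at this position. It shows that an open chain carrying 2 hydrogen-bond donors and 2 hydrogen-bond acceptors can give way to a six-membered ring of carbon only, with 0 of either, and the two compounds still cannot be told apart at the one concentration tested. No measurement shown here offers an explanation for this outcome.

The compounds shown leave open whether an amine or a carboxylic acid on this amide-type nitrogen's substituent, a longer chain, or a phenyl ring in place of cyclohexyl would give a number beyond the scatter of compound 2 and compound 3. Within the data shown here, they also leave open whether cyclohexyl in place of 2-methoxyethyl on the core of compound 1 would behave in the same way, since the only step at this position has been read on the core of compound 2.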